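Ring size on the amide carbonyl: compound 3 to compound 4

A few compounds are considered here, and "the series" means these few. Any claim that something is new, unique, unknown or untested is made for them only; others in the source may bear on it.

Measured compounds:
compound 1, `CCC(=O)N1CCC(c2cc(OC)ccc2N)=N1`, gives 20.4% in an assay on isolated protein for inhibition of Nitric oxide synthase, inducible (Homo sapiens), with a stated time of 30 min, tested at 1 mM; a lower number here means less inhibition, a higher number more inhibition at the concentration tested (going by the name of the read-out)
compound 2, `COc1ccc(N)c(C2=NN(C(=O)C3CCC3)CC2)c1`, gives 1.91%
compound 3, `COc1ccc(N)c(C2=NN(C(=O)C3CCCC3)CC2)c1`, gives 1.85%

Compound 3 stands at the lowest of the three numbers. Its nearest neighbour is compound 2, whose value lies within the scatter of it, while compound 1 sits well above both. Compound 4, `COc1ccc(N)c(C2=NN(C(=O)C3CCCCC3)CC2)c1`, differs from compound 3 in one place: cyclohexyl in place of cyclopentyl on a carbonyl carbon.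

Two kinds of step among the measured compounds bear on this. Exchanging ethyl for a cycloalkyl ring on the carbonyl carbon gave a number 18.5 percentage points lower from compound 1 to compound 2 (beyond the scatter) and a number 18.6 percentage points lower from compound 1 to compound 3 (beyond the scatter). Enlarging the ring by one carbon, however, gave a number 0.1 percentage points lower from compound 2 to compound 3 (within the scatter), a step within the scatter. The change to compound 4 is again an enlargement of the ring by one carbon, so no step beyond the scatter is expected; for compound 4 the expected step is a number 0.2 percentage points higher from compound 3 to compound 4 (within the scatter). Compound 4 is therefore estimated at 2% in this assay, with a range from 0% to 10%. Going by the values given here, with only one ring-enlargement step on record, this expectation rests on a single comparison.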

Compound 4, a percentage reported as inhibition, at one concentration (the size of the read-out at that concentration, not a potency): 13.3%
Compound 4: middle estimate off by 11.3 percentage points, on the low side; measured number above the stated range.
By their numbers in this assay, from the lowest: compounds 3 and 2 (each within the scatter of the next); then compounds 4 and 1 (each within the scatter of the next).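

In this assay, cyclohexyl on the carbonyl carbon separates from the two smaller rings, with a number 11.5 percentage points higher from compound 3 to compound 4 (beyond the scatter) and a number 11.4 percentage points higher from compound 2 to compound 4 (beyond the scatter), so the flat response between cyclobutyl and cyclopentyl does not carry over to the next ring size. A cycloalkyl ring at this position therefore does not by itself give the low numbers: with a number 7.1 percentage points lower from compound 1 to compound 4 (within the scatter), cyclohexyl stays within the scatter of ethyl, and compound 4 goes against any rule that rings read lower than ethyl. Nothing available accounts for the difference between the six-membered ring and the smaller rings.

On these data alone, whether cycloheptyl would read with cyclohexyl or apart from it remains open. Also open, as far as these compounds go, is where a longer chain such as butyl, or a ring carrying an amine, would fall at this position.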